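Ring swaps on the alkyne leave maximal response unchanged

The source may report more compounds than this note shows. Statements on the series, on what has been measured and on what is new or still open speak of the compounds shown alone.

Compound 1, `O=C(O)CCc1ccc(C#Cc2ccncc2)cc1`: 100%
Compound 2, `Cc1ccsc1C#Cc1ccc(CCC(=O)O)cc1`: 100%

In an in vitro functional assay on 1321-N1 cells for agonist activity at Free fatty acid receptor 1 (Homo sapiens), read by fluorescence, spectrophotometry and calcium flux (a lower number here means a smaller maximal response, a higher number a larger maximal response), compound 1 gives 100%. In the same test compound 2 gives 100%. Within the data shown here, the one step measured so far, no change at the digits printed from compound 1 to compound 2 (within the scatter), shows that exchanging the aromatic ring on the triple-bonded carbon left the maximal response flat. Compound 2 therefore stands level with compound 1 at the digits shown, within the usual scatter.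

Compound 3, `O=C(O)CCc1ccc(C#Cc2cncs2)cc1`, has not yet been measured. It differs from compound 2 in one place: 1,3-thiazol-5-yl in place of 3-methylthiophen-2-yl on a triple-bonded carbon. Among the measured compounds shown here, the only step that bears on this is no change at the digits printed from compound 1 to compound 2 (within the scatter), another exchange of the aromatic ring at the same place, and it brought no change beyond the scatter. For compound 3 in this assay no step beyond the scatter is therefore expected, no change at the digits printed from compound 2 to compound 3 (within the scatter). Compound 3 is estimated at 100%, between 85% and 110%.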

Compound 3, largest response reached (reported as efficacy), in percent of the reference or control that the assay uses: 99%
Beside the measured number, compound 3's estimate is 1 percentage points above it; the range from low to high includes it.
By their numbers in this assay, from the lowest: compounds 3, 1 and 2 (each within the scatter of the next).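

In this assay there is a number 1 percentage points lower from compound 2 to compound 3 (within the scatter), so a five-membered aromatic ring with 2 hetero atoms and no methyl group serves at this place on a triple-bonded carbon as well as the 3-methylthiophen-2-yl group does. There is also a number 1 percentage points lower from compound 1 to compound 3 (within the scatter), which means that the pyridin-4-yl, 3-methylthiophen-2-yl and 1,3-thiazol-5-yl groups cannot be told apart by maximal response. Nothing at hand explains why the response stays flat across these exchanges.

From the compounds shown here alone, all three compounds carry an aromatic ring with hetero atoms at this place, so it remains open whether a plain phenyl or a saturated cyclohexyl group would hold the response. Also open, going by these compounds, is what an amine on the ring would do, and whether potency follows maximal response across these compounds.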